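A few compounds are considered here, and "the series" means these few. Any claim that something is new, unique, unknown or untested is made for them only; others in the source may bear on it.

In a functional assay on HT-29 cells (Homo sapiens) for antiproliferative activity, read by MTT assay, with a stated time of 72 h (a higher number here means a weaker inhibitor, a lower number a stronger inhibitor), compound 1 `CNc1nc(-c2cc(OC)c(OC)c(OC)c2)c(-c2ccc(C)cc2)s1` gives 423 nM, while compound 2 `COc1cc(-c2nc(N(C)C)sc2-c2ccc(C)cc2)cc(OC)c1OC` gives 3920 nM, the higher of the two numbers. Compound 3 `COc1cc(-c2nc(C)sc2-c2ccc(C)cc2)cc(OC)c1OC` differs from compound 2 by methyl in place of dimethylamino on an aromatic carbon. Within the data shown here, the only measured step, a 9.3-fold higher number from compound 1 to compound 2 (0.97 log units; beyond the scatter), is methyl in place of hydrogen on a nitrogen, and it bears on this change only loosely. Among the measured compounds shown here, no measured step removes that nitrogen. In this assay, no shift beyond the scatter is expected, and the estimated step is a 1.6-fold lower number from compound 2 to compound 3 (0.20 log units; within the scatter). Compound 3 is expected at 2500 nM, with an estimated range of 500 nM to 12000 nM.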

Compound 3, half-maximal inhibitory concentration: 722 nM
Beside the measured number, compound 3's estimate is 3.5-fold (0.54 log units) above it, and the stated range covers the measured number.
By their numbers in this assay, from the lowest: compounds 1 and 3 (each within the scatter of the next); then compound 2.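

In this assay, methyl in place of dimethylamino on this aromatic carbon gives a 5.4-fold lower number from compound 2 to compound 3 (0.73 log units; beyond the scatter), so a nitrogen attached at this position is not required for the lower number. Methyl in place of methylamino gives a 1.7-fold higher number from compound 1 to compound 3 (0.23 log units; within the scatter), which leaves dimethylamino as the only one of the three groups that stands apart. Nothing available accounts for either step. The compounds shown leave open how a primary amine, an ethyl group or a plain hydrogen at this carbon would read.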